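Moving the Carboxy Chain Towards a Dimethylamino End

The compounds below may be only part of what the source reports. "The series", "measured", "known", "first", "only" and "open" are said of these compounds alone.

Compound 1 `COc1cc(C(=O)c2ccc3c(ccn3C)c2)cc(OC)c1OC`: 13.6 nM
Compound 2 `COc1cc(C(=O)c2ccc3c(ccn3CO)c2)cc(OC)c1OC`: 39 nM
Compound 3 `COc1cc(C(=O)c2ccc3c(ccn3CCC(=O)O)c2)cc(OC)c1OC`: > 10000 nM

All three compounds were tested in a functional assay on KB cells (Homo sapiens) for inhibition, with a stated time of 72 h; a lower number here means a stronger inhibitor, a higher number a weaker inhibitor. They share one core and differ only in the group on the aromatic nitrogen. The first change costs modestly: a 2.9-fold higher number from compound 1 to compound 2 (0.46 log units; beyond the scatter). Compound 3 gives > 10000 nM, which is a limit of the assay and not a number. It sits at the limit of > 10000 nM in this assay, at which 1 of the 3 values shown sits.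

The steps into compound 3 are large: an at least 730-fold higher number from compound 1 to compound 3 (2.86 log units; beyond the scatter), and an at least 250-fold higher number from compound 2 to compound 3 (2.40 log units; beyond the scatter). These two steps bear most directly on compound 4 `COc1cc(C(=O)c2ccc3c(ccn3CCN(C)C)c2)cc(OC)c1OC`, which carries 2-(dimethylamino)ethyl in place of 2-carboxyethyl: dimethylamino in place of carboxy on a saturated chain carbon, two bonds along the chain from an aromatic nitrogen. Compound 4 keeps the chain of compound 3 but loses the carboxy group, so a large step to a lower number is expected in this assay. For the measured compounds named here, a full return to the level of compound 1 at 13.6 nM is not expected, since no measured compound with a chain of this length shows such a value. The expected step is an at least 33-fold lower number from compound 3 to compound 4 (1.52 log units; beyond the scatter). For compound 4 the estimated value is 300 nM, with an expected range of 50 nM to 3000 nM.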

Compound 4, half-maximal inhibitory concentration: 5200 nM
Compound 4: middle estimate off by 17-fold (1.24 log units), on the low side; the measured number lies above the stated range.
By their numbers in this assay, from the lowest: compound 1; then compound 2; then compound 4. At a limit, above all of these: compound 3.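

Compound 3 stands at a limit of the assay, not at a number: the limit of > 10000 nM in this assay, at which 1 of the 4 values shown sits. Against that limit, putting dimethylamino in place of carboxy gives, in this assay, an at least 1.9-fold lower number from compound 3 to compound 4 (0.28 log units; that floor lies within the scatter), so removing the carboxy group is not shown to recover much at this position. The large cost remains with the 2-(dimethylamino)ethyl chain, at a 380-fold higher number from compound 1 to compound 4 (2.58 log units; beyond the scatter) and a 130-fold higher number from compound 2 to compound 4 (2.12 log units; beyond the scatter), so at this position the loss no longer rests on the carboxy group alone.

The compounds shown leave open whether the loss follows the length of the chain or the group at its end. They also leave open how a plain ethyl group, a 2-hydroxyethyl chain or a longer chain ending in an amine would read.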